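This account rests on a few compounds, and the source may have more. Where it says the series, first, only, none or still open, it means among the compounds named here.

Compound 1, `COc1cc(OC)cc(/C(=C\c2cn(C(C)=O)c3ccc(OCc4ccccc4)cc23)C(=O)O)c1`, gives 880 nM in a functional assay on DU-145 cells (Homo sapiens) for cytotoxicity, read by MTT assay, with a stated time of 72 h; a higher number here means a weaker inhibitor, a lower number a stronger inhibitor.
Compound 2, `COc1cc(/C(=C\c2cn(C(C)=O)c3ccc(OCc4ccccc4)cc23)C(=O)O)cc(OC)c1OC`, gives 950 nM.
Compound 3, `COc1ccc(/C(=C\c2cn(C(C)=O)c3ccc(OCc4ccccc4)cc23)C(=O)O)cc1`, gives 910 nM.

Compound 3 stands second highest of the three numbers, with compound 1 nearest and compound 2 furthest, and both gaps lie within the scatter: a 1.0-fold higher number from compound 1 to compound 3 (0.01 log units; within the scatter), a 1.0-fold lower number from compound 2 to compound 3 (0.02 log units; within the scatter). The third pair behaves the same way, a 1.1-fold higher number from compound 1 to compound 2 (0.03 log units; within the scatter), so the three methoxy patterns on this phenyl are indistinguishable here.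

Compound 4, `COc1ccccc1/C(=C\c1cn(C(C)=O)c2ccc(OCc3ccccc3)cc12)C(=O)O`, differs from compound 3 in one place: 2-methoxyphenyl in place of 4-methoxyphenyl on a double-bonded chain carbon bound to a carbonyl carbon and a double-bonded chain carbon. Among the compounds with values here, the steps that bear on it are the two that rearranged methoxy groups on the same phenyl, from compound 1 to compound 3 and from compound 2 to compound 3, and both stayed within the scatter. Within the data shown here, no measured step places a methoxy where compound 4 carries it, so the expectation rests on that flat pattern alone. Compound 4 is therefore expected to show no step beyond the scatter, a 1.0-fold higher number from compound 3 to compound 4 (0.02 log units; within the scatter), and compound 4 is estimated at 950 nM, within 420 nM to 2400 nM.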

Compound 4, half-maximal inhibitory concentration: 1010 nM
For compound 4 the middle estimate is 1.1-fold (0.03 log units) below the measured one, and the stated range covers the measured number.
By their numbers in this assay, from the lowest: compounds 1, 3, 2 and 4 (each within the scatter of the next).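

Placing the methoxy so that the group on the double-bonded chain carbon becomes 2-methoxyphenyl leaves the number in this assay within the scatter, a 1.1-fold higher number from compound 3 to compound 4 (0.05 log units; within the scatter). Within the data shown here, the same holds against the groups with more methoxy substituents, a 1.1-fold higher number from compound 2 to compound 4 (0.03 log units; within the scatter) and a 1.1-fold higher number from compound 1 to compound 4 (0.06 log units; within the scatter), so the flat pattern now extends to a methoxy placement that none of the earlier compounds carried, and the four methoxyphenyl groups cannot be told apart in this assay. Nothing available offers an explanation for this flatness.

From the compounds shown here alone, all four compounds carry methoxy on this phenyl, so it remains open whether a hydroxyl, a fluorine or an amine there would give a step beyond the scatter. Also open, going by these compounds, is what an ester or an amide in place of the carboxylic acid would do.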